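Chain variation on the ring nitrogen substituent: compound 2 to 3

A few compounds are considered here, and "the series" means these few. Any claim that something is new, unique, unknown or untested is made for them only; others in the source may bear on it.

Measured so far:
- compound 1 `CCCCC(=O)Nc1ncc(-c2cccc(Cl)c2)c(-c2ccccc2)n1`: 52%
- compound 2 `C#CCNc1ncc(-c2cccc(Cl)c2)c(-c2ccccc2)n1`: 76%

For the measured compounds named here, in an assay on CHO cells for displacement of a labelled ligand from adenosine receptor A1 (Homo sapiens), read by scintillation counting, with a stated time of 1 h, tested at 1 uM (a lower number here means less inhibition, a higher number more inhibition at the concentration tested (going by the name of the read-out)), compound 2 stands highest of the two numbers measured; the only other value, that of compound 1, is lower, and the step of a number 24 percentage points higher from compound 1 to compound 2 (beyond the scatter) is beyond the scatter. No third measured point exists to show whether compound 2 sits at a plateau or on a slope.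

Compound 3 `CCCCNc1ncc(-c2cccc(Cl)c2)c(-c2ccccc2)n1` is the next point. It differs from compound 2 as follows: propyl in place of ethynyl on a saturated chain carbon bound to a nitrogen on an aromatic ring

Going by the values given here, only one measured step is available, and it bears on the new step only loosely: it also alters the substituent on the nitrogen on the aromatic ring, but it exchanges butylcarbonyl for propargyl, whereas the step to compound 3 keeps the amine and exchanges ethynyl for propyl. Among the compounds with values here, no measured pair removes a triple bond or lengthens a saturated chain, so the direction of this step is not anchored by data. The shown step was modest in size; a change of similar or smaller size in this assay, in either direction, is the working expectation.

Compound 3 is expected to give about 66% in this assay, with the estimate ranging from 42% to 88%. That estimate corresponds to an expected step of a number 10 percentage points lower from compound 2 to compound 3 (within the scatter).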

Compound 3, a percentage reported as inhibition, at one concentration (the size of the read-out at that concentration, not a potency): 56%
For compound 3 the middle estimate is 10 percentage points above the measured one, within the range that was stated.
By their numbers in this assay, from the lowest: compounds 1 and 3 (each within the scatter of the next); then compound 2.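

In this assay, for the compounds shown here, the exchange of propargyl for butyl on the amine nitrogen gives a number 20 percentage points lower from compound 2 to compound 3 (beyond the scatter) and is the first measured change confined to the chain, with the amine kept in place. Removing the carbonyl while keeping a chain on that nitrogen gives a number 4 percentage points higher from compound 1 to compound 3 (within the scatter) and leaves the butyl amine and the butylcarbonyl amide indistinguishable here, so among these compounds only the propargyl amine stands apart, and the earlier rise on going to compound 2 does not follow from loss of the carbonyl alone. No evidence on the cause of either step is at hand.

The exchange of propargyl for butyl alters the triple bond and the chain length together, which leaves their separate contributions unresolved; a saturated propyl on the same nitrogen would separate them, and a butynyl chain would test a longer chain that keeps the triple bond. The compounds shown also leave open how the unsubstituted amine compares with these three, and whether the propargyl amine marks a peak in this series or lies short of one.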